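Adding a Chloro Group to the Shared Core

This account rests on a few compounds, and the source may have more. Where it says the series, first, only, none or still open, it means among the compounds named here.

Compound 1, `OCc1cn(Cc2cccc(F)c2)c2ccccc12`, gives in an ADME assay on T29 cells (Homo sapiens) for cytotoxicity, read by sulforhodamine B assay, with a stated time of 3 days (a lower number here means a stronger inhibitor, a higher number a weaker inhibitor), a value of > 31600 nM, which is a limit of the assay and not a number.
Compound 2, `OCc1cn(Cc2ccc(Cl)cc2)c2ccccc12`, gives in this assay a value of > 31600 nM, again a limit.
Compound 3, `OCc1cn(Cc2ccc(Cl)c(Cl)c2)c2ccccc12`, gives in this assay a value of > 31600 nM, also a limit.

All three measured values sit at the limit of > 31600 nM in this assay, at which 3 of the 3 values shown sit, so none of them is a number that can be compared. Compound 3 differs from compound 2 by chloro in place of hydrogen on an aromatic carbon, and the step that the two limits leave unreadable from compound 2 to compound 3. How the cores of compound 1 and compound 2 differ is not broken down here.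

Compound 4, `OCc1cn(Cc2cccc(F)c2)c2ccc(Cl)cc12`, is not yet measured. It differs from compound 1 by chloro in place of hydrogen on an aromatic carbon. Going by the values given here, this is the same kind of change as the one from compound 2 to compound 3, but the place is not the same: in compound 3 the chloro group enters ortho to a chloro group and meta to a large group, while in compound 4 it enters on a ring that is part of a fused system of two rings, meta to a fused ring and para to a fused ring.

Because all three measured values sit at the limit of > 31600 nM in this assay, at which 3 of the 3 values shown sit, compound 4 is expected to remain weak in this assay as well, and most likely to be reported only as a limit. The estimate for compound 4 is 45000 nM, within a range from 15000 nM to 150000 nM. The expected step is a step that the limit leaves unreadable from compound 1 to compound 4, which rests on nothing more than the shared limit.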

Compound 4, half-maximal inhibitory concentration: 10000 nM
For compound 4 the middle estimate is 4.5-fold (0.65 log units) above the measured one; measured number outside the range, below it.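

In this assay, placing chloro in place of hydrogen on the fused two-ring system gives an at least 3.1-fold lower number from compound 1 to compound 4 (0.49 log units; beyond the scatter), so this one change does lower the number on the core of compound 1. Compound 4 is also the only compound shown with a readable number rather than a limit, which makes this single pair the whole of the evidence for the effect. It does not show that the change carries from one core to another, since the same kind of change at a different place cannot be read, because the values of compound 2 and compound 3 are both limits of the assay: the limit of > 31600 nM in this assay, at which 3 of the 4 values shown sit.

Going by these compounds, it remains open whether chloro at this same place would also lower the number on the cores of compound 2 and compound 3. Also open, on these data alone, is whether the result is specific to chloro, or whether a methyl group, an amine or a carboxylic acid at that place would give a similar number.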